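Bromo in place of methyl: growth inhibition notes

This account rests on a few compounds, and the source may have more. Where it says the series, first, only, none or still open, it means among the compounds named here.

Within the data shown here, in a functional assay on MCF7 cells (Homo sapiens) for inhibition, read by sulforhodamine B assay, with a stated time of 48 h (a higher number here means a weaker inhibitor of growth, a lower number a stronger inhibitor of growth), compound 1 (`Cc1ccc(NC(=S)N/N=C/c2cccs2)cc1`) gives 38600 nM as the only actual number so far. Compound 2 (`C=CCNC(=S)N/N=C/c1cccs1`) reads > 100000 nM in this assay and that reading is a limit of the assay, not a number. Compound 3 (`S=C(N/N=C/c1cccs1)Nc1ccc(Br)cc1`) remains unmeasured. It carries bromo in place of methyl on an aromatic carbon, para to a large group. Among the measured compounds shown here, no measured step covers this exchange, so the expectation is anchored on compound 1 at 38600 nM in this assay alone. A change no larger than the usual scatter is expected, with a slight lean toward stronger growth inhibition. The estimated move is a 1.5-fold lower number from compound 1 to compound 3 (0.19 log units; within the scatter) and remains small. Compound 3 is expected at 25000 nM in this assay with an estimated range from 9000 nM to 60000 nM around that value.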

Compound 3, concentration for 50% growth inhibition: < 740 nM
Compound 3 gave a limit, no number (the forecaster's own chance of this, stated with the estimate: 10%); at least 33-fold (1.52 log units) between middle value and limit.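

In this assay, bromo in place of methyl on the six-membered aromatic ring, para to a large group, gives an at least 52-fold lower number from compound 1 to compound 3 (1.71 log units; beyond the scatter). No earlier pair offered a readable step, so this is the first sign that this place on the ring responds to a single-atom exchange, though it is shown for this one exchange only. Compound 3 reads < 740 nM, which is a limit of the assay and not a number, so the full size of the step cannot be read: the limit of < 740 nM in this assay, at which 1 of the 3 values shown sits.

The compounds shown leave open whether the response is particular to bromo or extends to chloro, fluoro or methoxy at the same place. They also leave open whether it persists when the shared core is changed elsewhere.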